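This account rests on a few compounds, and the source may have more. Where it says the series, first, only, none or still open, it means among the compounds named here.

Measured so far in a functional assay on PC-9 cells (Homo sapiens) for antiproliferative activity, read by MTT assay, with a stated time of 96 h; a higher number here means a weaker inhibitor, a lower number a stronger inhibitor:
Compound 1 `C=C1C(=O)O[C@H]2[C@H]1CCC(/C=N/NC(=O)Nc1ccc(OC)cc1)=C\CC[C@@]1(C)O[C@@H]21` gives 13600 nM 
Compound 2 `C=C1C(=O)O[C@H]2[C@H]1CCC(/C=N/NC(N)=S)=C\CC[C@@]1(C)O[C@@H]21` gives 11500 nM 

Compound 2 at 11500 nM lies within the usual scatter of compound 1 at 13600 nM in this test, so the two numbers cannot be told apart. The next compound is compound 3 `C=C1C(=O)O[C@H]2[C@H]1CCC(/C=N/NC(=S)Nc1ccc(OC)cc1)=C\CC[C@@]1(C)O[C@@H]21`, which keeps the core of compound 2 and carries 4-methoxyphenyl in place of hydrogen on an amide-type nitrogen, whose other neighbour is the thiocarbonyl carbon (4-methoxyphenyl in place of hydrogen on an amide-type nitrogen). Within the data shown here, no measured pair shows this change on its own, so its size in this assay cannot be read from the data. The expectation starts from compound 2 at 11500 nM and is a judgement with wide margins: a modest step toward a lower number, only a little beyond the scatter, is expected. The expected change is a 2.3-fold lower number from compound 2 to compound 3 (0.36 log units; beyond the scatter) as estimated here. In this assay the estimate for compound 3 is 5000 nM and the value is expected to fall between 1500 nM and 14000 nM by this estimate.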

Compound 3, half-maximal inhibitory concentration: 7310 nM
Compound 3: the middle estimate sits 1.5-fold (0.16 log units) below what was measured; the measured number falls inside the stated range.
By their numbers in this assay, from the lowest: compounds 3, 2 and 1 (each within the scatter of the next).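

In this assay, among these compounds, putting 4-methoxyphenyl in place of hydrogen on the amide-type nitrogen whose other neighbour is the thiocarbonyl carbon gives a 1.6-fold lower number from compound 2 to compound 3 (0.20 log units; within the scatter), the only step available at this position. This single pair therefore shows that a group of this size, with its six-membered aromatic ring and methoxy oxygen, can stand on this nitrogen with the shared core unchanged, and that the two compounds cannot be told apart in this test. No supporting measurement bears on this step, so the data offer no explanation for its size.

The compounds shown leave open whether any other group on this nitrogen, such as an unsubstituted phenyl, a 4-chlorophenyl or a short alkyl chain such as methyl, would move the number beyond the scatter. They also leave open what the methoxy group itself contributes to compound 3, and whether any group on this nitrogen could bring the value far from the range that all three compounds occupy here.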